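Cytotoxicity: pyridin-3-yl to 2-methylphenyl on the shared core

The source may hold more compounds than are shown below. What is called first, only, known or untested is meant among the compounds shown, and "the series" means these compounds.

Compound 1 `c1ccc(C(c2cccnc2)N2CCN(c3ncnc4c3cnn4-c3ccccc3)CC2)cc1` is measured in a functional assay on cells (Rhabdomyosarcoma cell, Homo sapiens) for cytotoxicity; on this read-out lower numbers stand for stronger inhibition and higher numbers for weaker inhibition. In this assay compound 1 gives > 25000 nM, which is a limit of the assay and not a number. Compound 2 `c1ccc(C(c2ccncc2)N2CCN(c3ncnc4c3cnn4-c3ccccc3)CC2)cc1` carries pyridin-4-yl in place of pyridin-3-yl on the same saturated chain carbon. In this assay compound 2 gives > 25000 nM, again a limit. The step that the two limits leave unreadable from compound 1 to compound 2 cannot be read because of the limit of > 25000 nM in this assay, at which 2 of the 2 values shown sit. Compound 3 `Cc1ccccc1C(c1ccccc1)N1CCN(c2ncnc3c2cnn3-c2ccccc2)CC1` differs from compound 1 as follows: 2-methylphenyl in place of pyridin-3-yl on a saturated chain carbon bound to an amine nitrogen in a ring and an aromatic carbon. Among the compounds with values here, no measured step bears on this change; the only measured step is the unreadable one between two limits, so there is no basis for expecting a shift beyond the scatter. The step of a number no higher from compound 1 to compound 3 (the limit leaves the size open) is therefore expected to be essentially flat, most likely ending again at a limit. Compound 3 is estimated at 25000 nM, within 8000 nM to 100000 nM in this assay.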

Compound 3, half-maximal inhibitory concentration: > 25000 nM
Compound 3 gave a limit, no number (the forecaster's own chance of this, stated with the estimate: 85%); the middle value lies on the limit itself.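

The steps among compound 1, compound 2 and compound 3 cannot be read in this assay, as all three sit at a limit, not a number: the limit of > 25000 nM in this assay, at which 3 of the 3 values shown sit. The compounds shown leave open whether any group at this place on the shared core gives a measurable value in this assay.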